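The source may report more compounds than this note shows. Statements on the series, on what has been measured and on what is new or still open speak of the compounds shown alone.

Measured so far in an assay on CHO cells for displacement of a labelled ligand from adenosine receptor A3 (Homo sapiens), read by scintillation counting; a lower number here means a stronger inhibitor, a higher number a weaker inhibitor:
Compound 1, `O=C(Nc1nc(-c2ccccc2)nc2c1nnn2Cc1ccccc1)c1ccc(Cl)cc1`, gives 3550 nM.
Compound 2, `O=C(Nc1nc(-c2ccccc2)nc2c1nnn2Cc1ccccc1)c1ccccc1F`, gives 5300 nM.
Compound 3, `O=C(Nc1nc(-c2ccccc2)nc2c1nnn2Cc1ccccc1)c1ccccc1C(F)(F)F`, gives 560 nM.

All three share one core and differ only in the aryl group on the carbonyl carbon. Compound 3 stands lowest of the three numbers: a 6.3-fold lower number from compound 1 to compound 3 (0.80 log units; beyond the scatter) and a 9.5-fold lower number from compound 2 to compound 3 (0.98 log units; beyond the scatter), both beyond the scatter, whereas a 1.5-fold higher number from compound 1 to compound 2 (0.17 log units; within the scatter).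

Compound 4, `Nc1ccc(C(=O)Nc2nc(-c3ccccc3)nc3c2nnn3Cc2ccccc2)cc1`, has not yet been measured. (4-aminophenyl in place of 2-(trifluoromethyl)phenyl on a carbonyl carbon). The two steps that bear on this both run toward 2-(trifluoromethyl)phenyl, which gave the lowest number, and the 4-chlorophenyl of compound 1 is the nearer comparison for 4-aminophenyl. Removing 2-(trifluoromethyl)phenyl is therefore expected to raise the number, by roughly a 5.4-fold higher number from compound 3 to compound 4 (0.73 log units; beyond the scatter). Compound 4 is estimated at 3000 nM, within a range of 800 nM to 12000 nM.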

Compound 4, inhibition constant: 926 nM
Beside the measured number, compound 4's estimate is 3.2-fold (0.51 log units) above it; measured number inside the range.
By their numbers in this assay, from the lowest: compounds 3 and 4 (each within the scatter of the next); then compounds 1 and 2 (each within the scatter of the next).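

In this assay, a low number does not depend on 2-(trifluoromethyl)phenyl: the switch on the carbonyl carbon gives a 1.7-fold higher number from compound 3 to compound 4 (0.22 log units; within the scatter) and leaves the two compounds within the scatter of each other. The group on the ring still counts, as amino in place of chloro gives a 3.8-fold lower number from compound 1 to compound 4 (0.58 log units; beyond the scatter) and 4-aminophenyl in place of 2-fluorophenyl gives a 5.7-fold lower number from compound 2 to compound 4 (0.76 log units; beyond the scatter) for the same carbonyl carbon. Nothing measured here explains these steps. Still open, as far as these compounds go, is whether a hydroxyl, a methoxy or a carboxylic acid in place of amino would give a similarly low number.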